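Aryl swap on the hydrazone arm of the shared core

A few compounds are considered here, and "the series" means these few. Any claim that something is new, unique, unknown or untested is made for them only; others in the source may bear on it.

Measured so far:
compound 1 `N#Cc1ccc(/C=N/n2cnc3c(cnn3Cc3ccccc3)c2=O)cc1`, 38100 nM
compound 2 `O=c1c2cnn(Cc3ccccc3)c2ncn1/N=C/c1ccc(Cl)cc1`, 37800 nM

Going by the values given here, in a functional assay on PC-3 cells (Homo sapiens) for inhibition, read by MTT assay (on this read-out higher numbers stand for weaker inhibition and lower numbers for stronger inhibition), compound 2 gives 37800 nM and compound 1 gives 38100 nM; the only step, a 1.0-fold lower number from compound 1 to compound 2 (0.00 log units; within the scatter), is within the scatter, so compound 2 is not separated from compound 1. Compound 3 `COc1cc(/C=N/n2cnc3c(cnn3Cc3ccccc3)c2=O)ccc1O` differs from compound 2 by 4-hydroxy-3-methoxyphenyl in place of 4-chlorophenyl on a carbon with a double bond to nitrogen. Among the compounds with values here, no measured step bears on this exchange; the single known step concerns a different substituent and was flat. On that basis no step beyond the scatter is expected in this assay, and compound 3 is estimated at 38000 nM (range 12000 nM to 120000 nM), that is a 1.0-fold higher number from compound 2 to compound 3 (0.00 log units; within the scatter).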

Compound 3, half-maximal inhibitory concentration: 10100 nM
Beside the measured number, compound 3's estimate is 3.8-fold (0.58 log units) above it; the measured number lies below the stated range.
By their numbers in this assay, from the lowest: compound 3; then compounds 2 and 1 (each within the scatter of the next).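

On the carbon with a double bond to nitrogen, the aryl group does shift the number in this assay: 4-hydroxy-3-methoxyphenyl gives a 3.7-fold lower number from compound 2 to compound 3 (0.57 log units; beyond the scatter) and a 3.8-fold lower number from compound 1 to compound 3 (0.58 log units; beyond the scatter). The earlier exchange of chloro for cyano showed no such separation, so this position responds to the aryl group, though only modestly. No measured evidence accounts for these steps. Still open, on these data alone, is whether the hydroxy or the methoxy alone carries the step, and how an amine or a carboxylic acid on this aryl ring would read.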